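Adding a Diethylamino Group to a Stilbene-Chalcone Scaffold

The source may hold more compounds than are shown below. What is called first, only, known or untested is meant among the compounds shown, and "the series" means these compounds.

Measured compounds:
- compound 1, `COc1ccc(/C=C/c2cc(OC)cc(OC)c2/C=C/C(=O)c2cccc(Cl)c2)cc1`: 5.6 ug/mL
- compound 2, `COc1ccc(/C=C/c2cc(OC)cc(OC)c2/C=C/C(=O)c2ccccc2)cc1`: 3.9 ug/mL

In a functional assay on A549 cells (Homo sapiens) for antiproliferative activity, read by MTT assay, with a stated time of 48 h (on this read-out lower numbers stand for stronger inhibition and higher numbers for weaker inhibition), compound 2 gives 3.9 ug/mL, and compound 1 gives 5.6 ug/mL; the two values sit within the scatter of each other, so neither can be called the more potent one. For the measured compounds named here, the only measured step, a 1.4-fold lower number from compound 1 to compound 2 (0.16 log units; within the scatter), swaps chloro for hydrogen on the ketone-bearing ring and changes nothing beyond the scatter.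

Compound 3, `CCN(CC)c1ccc(C(=O)/C=C/c2c(/C=C/c3ccc(OC)cc3)cc(OC)cc2OC)cc1`, has not yet been measured in this assay. It differs from compound 2 by diethylamino in place of hydrogen on an aromatic carbon. Going by the values given here, no measured step adds such a group, so nothing here bears directly on it; the one step known concerns a different substituent and was within the scatter. Compound 3 is therefore expected to land near compound 2, with a step of a 1.2-fold higher number from compound 2 to compound 3 (0.06 log units; within the scatter) and a wide range. The estimate for compound 3 is 4.5 ug/mL, between 1.5 ug/mL and 14 ug/mL.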

Compound 3, half-maximal inhibitory concentration: 5.4 ug/mL
For compound 3 the middle estimate is 1.2-fold (0.08 log units) below the measured one; the range from low to high includes it.
By their numbers in this assay, from the lowest: compounds 2, 3 and 1 (each within the scatter of the next).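

Placing diethylamino on an aromatic carbon of the ketone-bearing ring, para to a large group, gives a 1.4-fold higher number from compound 2 to compound 3 (0.14 log units; within the scatter) in this assay and shows that this position can carry a group of 5 heavy atoms with no change beyond the scatter. Exchanging the whole 3-chlorophenyl for 4-(diethylamino)phenyl gives a 1.0-fold lower number from compound 1 to compound 3 (0.02 log units; within the scatter) and so does not separate these two rings either. Nothing measured here offers a reason for this result.

As far as these compounds go, whether a primary amine, a carboxylic acid or a longer chain on the same carbon would also leave the number within the scatter remains open. So does the question of whether diethylamino would give the same result on another carbon of this ring.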